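Pyridin-2-yl carbonyl replacing hydroxyphenyl carbonyl: cytotoxicity notes

The source may hold more compounds than are shown below. What is called first, only, known or untested is meant among the compounds shown, and "the series" means these compounds.

Measured in an ADME assay on Karpas-1106P cells (Homo sapiens) for cytotoxicity; a lower number here means that less compound is needed, a higher number that more compound is needed for the effect:
compound 1 `Cc1ccc(S(=O)(=O)N[C@@H](CC(=O)NC(C)(C)C)C(=O)NCCNC(=O)c2c(O)cccc2F)cc1`: > 11100 nM, a limit of the assay.
compound 2 `Cc1ccc(S(=O)(=O)N[C@@H](CC(=O)NC(C)(C)C)C(=O)NCCNC(=O)c2cccc(O)c2)cc1`: > 11100 nM, a limit of the assay.
compound 3 `Cc1ccc(S(=O)(=O)N[C@@H](CC(=O)NC(C)(C)C)C(=O)NCCNC(=O)c2ccccc2O)cc1`: > 11100 nM, a limit of the assay.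

In this assay, going by the values given here, compound 2 stands only as a limit, and the two other values shown are limits as well; no compound of the series has given a number. Among the compounds with values here, the steps that bear on the carbonyl-attached ring are a step that the two limits leave unreadable from compound 1 to compound 2, a step that the two limits leave unreadable from compound 1 to compound 3 and a step that the two limits leave unreadable from compound 2 to compound 3, none of which can be read in size, since all three values sit at the limit of > 11100 nM in this assay, at which 3 of the 3 values shown sit.

Compound 4 `Cc1ccc(S(=O)(=O)N[C@@H](CC(=O)NC(C)(C)C)C(=O)NCCNC(=O)c2ccccn2)cc1` is not yet measured. It differs from compound 2 in one place: pyridin-2-yl in place of 3-hydroxyphenyl on a carbonyl carbon. Within the data shown here, nothing among the measured steps distinguishes one ring on this carbonyl from another, so no direction can be drawn for the change. The expectation is therefore that compound 4 will again be reported as a limit rather than a number, the step from compound 2 being estimated as a step that the limit leaves unreadable from compound 2 to compound 4. The estimate for compound 4 in this assay is 15000 nM, within a range from 5000 nM to 40000 nM.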

Compound 4, half-maximal effective concentration: > 11100 nM
Compound 4: no number, only a limit (the forecaster's own chance of this, stated with the estimate: 85%); the middle value does not contradict the limit.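

In this assay compound 4 is again only a limit and not a number, so its steps to compound 1, compound 2 and compound 3 cannot be read in size: the limit of > 11100 nM in this assay, at which 4 of the 4 values shown sit.

Whether pyridin-2-yl, 3-hydroxyphenyl, 2-hydroxyphenyl and 2-fluoro-6-hydroxyphenyl on this carbonyl carbon differ at all in this assay stays open, with no number among the compounds shown.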